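A few compounds are considered here, and "the series" means these few. Any claim that something is new, unique, unknown or untested is made for them only; others in the source may bear on it.

In a functional assay on PLC-PRF-5 cells (Homo sapiens) for inhibition (a higher number here means a weaker inhibitor, a lower number a stronger inhibitor), compound 1 `CNC(=O)c1cc(Oc2ccc(NS(=O)(=O)c3ccccc3)cc2)ccn1` gives only a limit of the assay, > 40000 nM. Compound 2 `CNC(=O)c1cc(Oc2ccc(NS(=O)(=O)c3ccccc3[N+](=O)[O-])cc2)ccn1` carries the change nitro in place of hydrogen on an aromatic carbon on that core. In this assay compound 2 likewise gives only a limit, > 40000 nM. The step that the two limits leave unreadable from compound 1 to compound 2 therefore cannot be sized because of the limit of > 40000 nM in this assay, at which 3 of the 3 values shown sit. Compound 3 `O=S(=O)(Nc1ccc(Oc2ccnc3ccccc23)cc1)c1ccc(C(F)(F)F)cc1Br` rests on a different core; the difference between the two cores is not broken down here. In this assay compound 3 also gives only a limit, > 40000 nM. Compound 4 `O=[N+]([O-])c1cccc2c(Oc3ccc(NS(=O)(=O)c4ccc(C(F)(F)F)cc4Br)cc3)ccnc12` has not been measured and differs from compound 3 by nitro in place of hydrogen on an aromatic carbon. This is the same kind of change as that from compound 1 to compound 2, though the surroundings differ: in compound 2 the nitro sits ortho to a large group, whereas in compound 4 it sits on a ring that is part of a fused or bridged system of two rings, ortho to a fused ring and meta to a fused ring. The step that the limit leaves unreadable from compound 3 to compound 4 is expected to be as unreadable as the earlier one, an expectation resting on the fact that (the limit of > 40000 nM in this assay, at which 3 of the 3 values shown sit). Compound 4 is expected to sit at 60000 nM, within 20000 nM to 200000 nM, with the assay most likely reporting only a limit again.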

Compound 4, half-maximal inhibitory concentration: > 40000 nM
Compound 4 gave a limit, no number; the forecaster's own chance of this, stated with the estimate: 85%; the middle value lies beyond the limit too.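

In this assay, within the data shown here, compound 4 gives only a limit of the assay, > 40000 nM, so no size can be read for its step from compound 3, and no new step results: the limit of > 40000 nM in this assay, at which 4 of the 4 values shown sit. The compounds shown leave open whether nitro in place of hydrogen on an aromatic carbon alters inhibition at all, and which structures would give a number in this assay.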